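Trimming an Ethyl Group to a Methyl

The source may report more compounds than this note shows. Statements on the series, on what has been measured and on what is new or still open speak of the compounds shown alone.

Compound 1 `CCC(=O)N[C@@H]1CCCc2c1cncc2N1C(=O)c2ccc(Cl)cc2[C@@H]1C`: < 20.2 mL/min/kg (a limit, not a number)
Compound 2 `CCC1c2cc(Cl)ccc2C(=O)N1c1cccnc1`: 65.9 mL/min/kg

Both results come from an ADME assay on microsomes from liver (Mus musculus) for metabolic stability, read by LC-MS, using NADPH, with stated times of 10 min and 30 min; a higher number here means faster removal of the compound, a lower number slower removal. Within the data shown here, compound 2, with 65.9 mL/min/kg, holds the only exact number so far. Compound 1 is reported only as a limit, < 20.2 mL/min/kg.

Compound 3 `CC1c2cc(Cl)ccc2C(=O)N1c1cccnc1` has not yet been measured. It differs from compound 2 in one place: hydrogen in place of methyl on a saturated chain carbon bound to a saturated ring carbon. This is hydrogen in place of methyl on a saturated chain carbon bound to a saturated ring carbon, which turns ethyl into methyl. Among the measured compounds shown here, no measured pair of compounds shows what this change does in this assay. The change is small, and any shift from the 65.9 mL/min/kg of compound 2 is expected to stay within the usual scatter, leaning slightly towards slower removal. The expected step is a 1.3-fold lower number from compound 2 to compound 3 (0.10 log units; within the scatter). For compound 3 the estimated clearance is 52 mL/min/kg, with an expected range from 28 mL/min/kg to 95 mL/min/kg.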

Compound 3, clearance: 66.5 mL/min/kg
The estimate for compound 3 lay 1.3-fold (0.11 log units) below the measured number; the measured number falls inside the stated range.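

Trimming ethyl to methyl at this position gives a 1.0-fold higher number from compound 2 to compound 3 (0.00 log units; within the scatter) in this assay, the first direct reading of this change. Compound 2 and compound 3 read alike, so across this pair the one carbon that leaves the chain makes no difference that can be told from the usual scatter of repeated measurements. Nothing measured here gives a reason for this result.

Still open, on these data alone, is whether a longer chain such as propyl, or an amine on the same saturated ring carbon, would also read like compound 2 and compound 3. This single pair also cannot say whether turning ethyl into methyl would read the same way on a different core.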